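The compounds below may be only part of what the source reports. "The series", "measured", "known", "first", "only" and "open" are said of these compounds alone.

Measured compounds:
Compound 1 `CN(C)CCN1CCN(CC(=O)Nc2ccc(-c3nc4cc(Cl)ccc4o3)cc2)CC1`: 28700 nM
Compound 2 `Cc1ccc2oc(-c3ccc(NC(=O)CN4CCN(CCCN(C)C)CC4)cc3)nc2c1`: 26400 nM

In an ADME assay on NIH3T3 cells (Mus musculus) for cytotoxicity, read by MTT assay, with a stated time of 24 h (a higher number here means a weaker inhibitor, a lower number a stronger inhibitor), compound 1 gives 28700 nM. In this assay compound 2 gives 26400 nM. The two numbers sit within the scatter of each other, so neither compound can be told apart from the other on this measure; compound 2 simply has the smaller of the two readings.

Compound 3 `CN(C)CCCN1CCN(CC(=O)Nc2ccc(-c3nc4cc(Cl)ccc4o3)cc2)CC1` has not yet been measured. It differs from compound 2 in one place: chloro in place of methyl on an aromatic carbon. Compound 1 already carries the same chloro group, joined to a shorter chain, and its reading lies within the scatter of compound 2, which gives no reason to expect a shift here beyond the scatter. For compound 3 the step of a 1.0-fold higher number from compound 2 to compound 3 (0.01 log units; within the scatter) is expected to stay inside the usual scatter. Compound 3 is therefore estimated at 27000 nM, with a likely range from 14000 nM to 55000 nM.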

Compound 3, half-maximal inhibitory concentration: 25800 nM
For compound 3 the middle estimate is 1.0-fold (0.02 log units) above the measured one; measured number inside the range.
By their numbers in this assay, from the lowest: compounds 3, 2 and 1 (each within the scatter of the next).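

In this assay, chloro in place of methyl on the aromatic carbon, read as 5-methyl-1,3-benzoxazol-2-yl to 5-chloro-1,3-benzoxazol-2-yl, gives a 1.0-fold lower number from compound 2 to compound 3 (0.01 log units; within the scatter), so methyl and chloro cannot be told apart at this position on this measure. With chloro kept in place, (dimethylamino)methyl in place of dimethylamino on the chain gives a 1.1-fold lower number from compound 1 to compound 3 (0.05 log units; within the scatter), so these two chain lengths cannot be told apart either, a comparison that compound 1 and compound 2 could not offer because they differ in more than one place. Nothing shown offers an explanation for these readings.

Among these compounds, only methyl and chloro appear at this position, and only two chain lengths appear. As far as these compounds go, whether a methoxy group or a carboxylic acid at this position, or a longer chain, would give a step beyond the scatter remains open.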